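The compounds below may be only part of what the source reports. "The series", "measured", "known", "first", "only" and "open" are said of these compounds alone.

Measured compounds:
compound 1, `Cc1c(Cl)ccc(S(=O)(=O)N(C)CCOCC(=O)N(C)Cc2ccc(C3=NCCN3)cc2)c1Cl`, 7.5
compound 2, `CN(Cc1ccc(C2=NCCN2)cc1)C(=O)COCCN(C)S(=O)(=O)c1ccc(OC(F)(F)F)cc1`, "not determined" (no result reported)

In a functional assay for antagonist activity at B1 bradykinin receptor (Mus musculus), using Schild analysis, with a stated time of 30 min (a lower number here means a less potent compound, a higher number a more potent compound, by a factor of ten per unit of this negative logarithm), compound 1 gives 7.5. Compound 2 stands without a single number in this assay; its entry reads "not determined" (no result reported). Compound 3, `CN(Cc1ccc(C2=NCCN2)cc1)C(=O)COCCN(C)S(=O)(=O)c1c(F)cccc1F`, differs from compound 2 by 2,6-difluorophenyl in place of 4-(trifluoromethoxy)phenyl on a sulfonyl sulfur. Among the measured compounds shown here, no measured step between related compounds exists here, so only compound 1, which carries a different group on the sulfonyl sulfur, serves as a loose reference; a modest shift in either direction, possibly beyond the scatter, is plausible. Compound 3 is expected to give about 6.9, with a range from 6.1 to 7.7.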

Compound 3, negative logarithm of the antagonist equilibrium constant: 6
The estimate for compound 3 lay 0.90 log units above the measured number; measured number below the stated range.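

In this assay, among the compounds shown here, the group on the sulfonyl sulfur clearly matters: with the rest of the structure shared, 2,6-difluorophenyl in place of 2,4-dichloro-3-methylphenyl gives a number 1.50 log units lower from compound 1 to compound 3 (beyond the scatter), the first readable step at this position. Nothing measured here bears on why the potency falls.

For the compounds shown here, compound 2 has no number, so no step involving it can be read, and the standing of 4-(trifluoromethoxy)phenyl stays unknown. Also open, as far as these compounds go, is where an unsubstituted phenyl or a pyridine on the sulfonyl sulfur would fall.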